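A swap to 3-chloro-4-fluorophenyl: expectations for compound 4

The source may report more compounds than this note shows. Statements on the series, on what has been measured and on what is new or still open speak of the compounds shown alone.

Compound 1 `CCOc1ccc(NC(=O)Nc2cccc(CNc3nccnc3Cl)c2)cc1`: 9080 nM
Compound 2 `O=C(Nc1ccc(Cl)cc1)Nc1cccc(CNc2nccnc2Cl)c1`: 5470 nM
Compound 3 `O=C(Nc1cccc(Cl)c1)Nc1cccc(CNc2nccnc2Cl)c1`: 6810 nM

All three compounds were tested in a functional assay on T-24 cells (Homo sapiens) for antiproliferative activity, read by MTT assay, with a stated time of 48 h; on this read-out higher numbers stand for weaker inhibition and lower numbers for stronger inhibition. Compound 2 cannot be separated from either of the other two on these numbers: the data show a 1.7-fold lower number from compound 1 to compound 2 (0.22 log units; within the scatter) and a 1.2-fold higher number from compound 2 to compound 3 (0.10 log units; within the scatter).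

Compound 4 `O=C(Nc1cccc(CNc2nccnc2Cl)c1)Nc1ccc(F)c(Cl)c1` has not yet been measured. It keeps the core of compound 2 and differs in one group: 3-chloro-4-fluorophenyl in place of 4-chlorophenyl on an amide-type nitrogen. In words, 3-chloro-4-fluorophenyl stands in place of 4-chlorophenyl on an amide-type nitrogen.

The nearest evidence is the exchange of 4-chlorophenyl for 3-chlorophenyl, which gave a 1.2-fold higher number from compound 2 to compound 3 (0.10 log units; within the scatter). Replacing 4-ethoxyphenyl with 3-chlorophenyl gave a 1.3-fold lower number from compound 1 to compound 3 (0.12 log units; within the scatter). Neither step left the scatter, and neither points to a direction for the new group. For the measured compounds named here, no measured compound carries the 3-chloro-4-fluorophenyl group, so the expectation rests on these small steps alone. In this assay, no change beyond the scatter is therefore expected. The expected step is a 1.1-fold lower number from compound 2 to compound 4 (0.04 log units; within the scatter). Compound 4 is estimated at 5000 nM, with an expected range from 2500 nM to 10000 nM.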

Compound 4, half-maximal inhibitory concentration: 4990 nM
The estimate for compound 4 lay 1.0-fold (0.00 log units) above the measured number; measured number inside the range.
By their numbers in this assay, from the lowest: compounds 4, 2, 3 and 1 (each within the scatter of the next).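

In this assay, the 3-chloro-4-fluorophenyl group on the amide-type nitrogen gave a 1.1-fold lower number from compound 2 to compound 4 (0.04 log units; within the scatter) and fluoro in place of hydrogen on an aromatic carbon gave a 1.4-fold lower number from compound 3 to compound 4 (0.14 log units; within the scatter), so carrying both halogens on one phenyl group could not be separated from carrying chlorine alone. Even the exchange for 4-ethoxyphenyl, the largest step among these four compounds, gave a 1.8-fold lower number from compound 1 to compound 4 (0.26 log units; within the scatter), which extends to a doubly substituted group what the earlier compounds showed only for singly substituted ones: every exchange at this position so far has stayed inside the scatter. No accompanying measurement offers any explanation for why these numbers stay so close together.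

The compounds shown leave open whether any group at this position can move the number beyond the scatter, since they cover only chloro, fluoro and ethoxy on the phenyl group. An amine or a carboxylic acid on that phenyl group, or a longer chain in place of the ethoxy, would test this position with substituents quite unlike those seen here.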